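Benzylamide replaces tertiary amide in a Toll-like receptor 8 series

The compounds below may be only part of what the source reports. "The series", "measured", "known", "first", "only" and "open" are said of these compounds alone.

Measured so far:
compound 1, `CCCCNc1nc(N)nc2cccc(C(=O)NC)c12`: 0.39 uM
compound 2, `CCCCNc1nc(N)nc2cccc(C(=O)N(C)C(C)C)c12`: > 25 uM

In an ADME assay on HEK293 cells for agonist activity at Toll-like receptor 8 (Homo sapiens), read by a luciferase reporter, with a stated time of 6 h (on this read-out lower numbers stand for an effect already at smaller amounts and higher numbers for an effect only at larger amounts of compound), compound 1 gives 0.39 uM. Compound 2 gives only a limit of the assay, > 25 uM; the pair is described by the limit of > 25 uM in this assay, at which 1 of the 2 values shown sits. Among the measured compounds shown here, the single measured step, an at least 64-fold higher number from compound 1 to compound 2 (1.80 log units; beyond the scatter), comes from isopropyl in place of hydrogen on an amide-type nitrogen.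

Compound 3, `CCCCNc1nc(N)nc2cccc(C(=O)NCc3ccccc3)c12`, has not yet been tested. It differs from compound 2 by benzylamino in place of isopropyl(methyl)amino on a carbonyl carbon. For the measured compounds named here, the group that enters again carries a hydrogen-bond donor, as the amide of compound 1 does, while the group that leaves is the one whose arrival in compound 2 went with the large rise in the measured number. On that basis the step to compound 3 is expected to run downward, back toward the number of compound 1, as an at least 25-fold lower number from compound 2 to compound 3 (1.39 log units; beyond the scatter). Compound 3 is therefore estimated at 1 uM, expected between 0.2 uM and 8 uM.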

Compound 3, minimum effective concentration: 1.6 uM
Compound 3: the middle estimate sits 1.6-fold (0.20 log units) below what was measured; the measured number falls inside the stated range.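

In this assay, benzylamino on the carbonyl carbon brings back most of what isopropyl(methyl)amino lost, with an at least 15-fold lower number from compound 2 to compound 3 (1.19 log units; beyond the scatter). Benzylamino has the higher heavy-atom count of the two groups and still gives the lower number, so among these compounds the number does not simply follow the size of the group on this carbonyl carbon. The added phenyl still has a modest cost, with a 4.1-fold higher number from compound 1 to compound 3 (0.61 log units; beyond the scatter), while compound 2 stands only at a limit, so the true size of its step remains unknown: the limit of > 25 uM in this assay, at which 1 of the 3 values shown sits.

The compounds shown cannot separate the loss of the amide hydrogen from the arrival of the isopropyl group in compound 2. A dimethylamino group on this carbonyl carbon would bear on that question, and a phenethylamino group would show how the number responds to a longer link to the ring.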